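Ester and ring swaps in a dihydropyrimidinone series

The source may hold more compounds than are shown below. What is called first, only, known or untested is meant among the compounds shown, and "the series" means these compounds.

Among the measured compounds shown here, compound 2 `CC1=C(C(=O)OCC(C)C)C(c2ccco2)NC(=O)N1C` stands lowest of the three measured members: in an assay on membranes from CHO cells for displacement of a labelled ligand from adenosine receptor A1 (Homo sapiens), read by scintillation counting, with a stated time of 60 min, tested at 1 uM (a higher number here means more inhibition at the concentration tested (going by the name of the read-out), a lower number less inhibition), compound 2 gives 13%, while compound 1 `COC(=O)C1=C(C)N(C)C(=O)NC1c1ccco1` gives 45% and compound 3 `CC1=C(C(=O)OC(C)(C)C)C(c2ccco2)NC(=O)N1C` gives 44%. Every measured step concerns the ester only: a number 32 percentage points lower from compound 1 to compound 2 (beyond the scatter), a number 1 percentage points lower from compound 1 to compound 3 (within the scatter) and a number 31 percentage points higher from compound 2 to compound 3 (beyond the scatter). Compound 4 `CC1=C(C(=O)OCC(C)C)C(c2cccs2)NC(=O)N1C` differs from compound 2 at a different place: thiophen-2-yl in place of furan-2-yl on a saturated ring carbon. For the measured compounds named here, no measured pair changes this ring, so none of the steps bears directly on the swap; the two rings are counted alike in what they carry. With nothing measured pointing to a shift, the step is expected to stay within the scatter, a number 7 percentage points higher from compound 2 to compound 4 (within the scatter). Compound 4 is therefore estimated at 20% in this assay, within 5% to 45%.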

Compound 4, a percentage reported as inhibition, at one concentration (the size of the read-out at that concentration, not a potency): 9%
Compound 4: middle estimate off by 11 percentage points, on the high side; measured number inside the range.
By their numbers in this assay, from the lowest: compounds 4 and 2 (each within the scatter of the next); then compounds 3 and 1 (each within the scatter of the next).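

In this assay, among the compounds shown here, the first reading at this position is a number 4 percentage points lower from compound 2 to compound 4 (within the scatter), so with the isobutoxycarbonyl group in place, thiophen-2-yl and furan-2-yl cannot be told apart. This holds for one ester only, and at the low end of the series. Nothing at hand speaks to the reason for this outcome.

Going by these compounds, whether the swap stays as quiet on the methyl ester, where compound 1 gives 45%, remains open. So does the reading of a phenyl or pyridin-2-yl group on this saturated ring carbon.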